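This account rests on a few compounds, and the source may have more. Where it says the series, first, only, none or still open, it means among the compounds named here.

Compound 1 `CC(C)CCn1nc(-c2cccs2)c(O)c(C2=NS(=O)(=O)c3cc(NS(=O)(=O)C(C)C)ccc3N2)c1=O`: > 1000 nM (a limit)
Compound 2 `CCCS(=O)(=O)Nc1ccc2c(c1)S(=O)(=O)N=C(c1c(O)c(-c3cccs3)nn(CCC(C)C)c1=O)N2`: > 1000 nM (a limit)
Compound 3 `CC(C)CCn1nc(-c2cccs2)c(O)c(C2=NS(=O)(=O)c3cc(N(C(C)C)S(C)(=O)=O)ccc3N2)c1=O`: "not determined" (no result reported)

The read-out here comes from an ADME assay on Huh-7 cells (Homo sapiens) for cytotoxicity, with a stated time of 72 h; a higher number here means that more compound is tolerated, a lower number that less compound is tolerated. Compound 1 has no exact number, only a limit of > 1000 nM. Compound 2 also stands at a limit, > 1000 nM. Compound 3 offers no result to compare.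

Compound 4 `CC(C)CCn1nc(-c2cccs2)c(O)c(C2=NS(=O)(=O)c3cc(CS(C)(=O)=O)ccc3N2)c1=O` carries a new group on the core of compound 1: (methylsulfonyl)methyl in place of (isopropylsulfonyl)amino on an aromatic carbon. Going by the values given here, in words, this is (methylsulfonyl)methyl in place of (isopropylsulfonyl)amino on an aromatic carbon, at a different kind of group from the one changed in the only measured step.

That step, propyl in place of isopropyl on a sulfonyl sulfur, is a step that the two limits leave unreadable from compound 1 to compound 2, so it provides no size to carry over. Among the compounds with values here, no clear step in this assay is expected in either direction because the limit of > 1000 nM in this assay, at which 2 of the 3 values shown sit, is the only guide. The estimated change is a step that the limit leaves unreadable from compound 1 to compound 4.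

For compound 4 the expected value is 1500 nM, with an estimated range of 700 nM to 10000 nM.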

Compound 4, half-maximal cytotoxic concentration: > 33000 nM
Compound 4 ended at the assay's limit (the forecaster's own chance of this, stated with the estimate: 80%); middle value at least 22-fold (1.34 log units) away from the limit.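

Compound 4 gives only a limit, > 33000 nM, not an exact number. Going by these compounds alone, compounds 1 and 2 also give only limits, so no step to compound 4 can be read. On these data alone, whether (methylsulfonyl)methyl in place of (isopropylsulfonyl)amino changes how much compound is tolerated stays open.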